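The source may report more compounds than this note shows. Statements on the series, on what has been measured and on what is new or still open speak of the compounds shown alone.

Measured so far, in a functional assay on PC-3 cells (Homo sapiens), read by fluorescence and BrdU incorporation, with a stated time of 48 h, tested at 10 uM; a higher number here means a weaker effect of the compound at the concentration tested, a lower number a stronger effect:

Compound 1, `COc1cc(OC)c(C(=O)/C=C/c2ccc(Cl)cc2)c(OC)c1`, gives 15% in this assay.
Compound 2, `COc1cccc(/C=C/C(=O)c2c(O)cc(OC)cc2OC)c1`, gives 39% in this assay.
Compound 3, `COc1cc(O)c(C(=O)/C=C/c2ccccc2SC)c(OC)c1`, gives 35% in this assay.

All three share the same core, a chalcone-type scaffold, and differ only in the groups carried on the two rings. Among them compound 1 has the lowest number, and so the strongest effect in this assay: the nearest of the other two is compound 3, whose number lies higher by a margin beyond the usual scatter, and compound 2 stands further off still, also beyond the scatter.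

The step considered here leads from compound 1 to compound 4, `COc1cc(OC)c(C(=O)/C=C/c2ccc(F)cc2)c(OC)c1`, which has not yet been measured. The change is a small one: fluoro in place of chloro on an aromatic carbon. For the measured compounds named here, no measured pair here shows what this swap does, so the expectation rests on compound 1 alone. The expected step from compound 1 to compound 4 in this assay is a number 10 percentage points higher from compound 1 to compound 4 (within the scatter), that is, a modest move toward a weaker effect that may well stay within the scatter. For compound 4 the estimate in this assay is 25%, with a range from 8% to 50%.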

Compound 4, a percentage reported as activity, at one concentration (the size of the read-out at that concentration, not a potency): 27%
Compound 4: middle estimate off by 2 percentage points, on the low side, within the range that was stated.
By their numbers in this assay, from the lowest: compound 1; then compounds 4, 3 and 2 (each within the scatter of the next, the first and the last beyond it).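

For the compounds shown here, compounds 1 and 4 are the only pair here that differ in one place, so this step isolates a single change on the shared core. In this assay, going from chloro to fluoro on an aromatic carbon, para to a large group, gives a number 12 percentage points higher from compound 1 to compound 4 (beyond the scatter), a shift toward a weaker effect. The two halogens are therefore not interchangeable at this position, even though only one heavy atom is exchanged, but nothing available here explains why the step goes this way.

Going by these compounds, it remains open how an amine, a carboxylic acid or a longer chain at this position would compare with chloro and fluoro. It is also unknown whether the same swap would produce a similar step on a version of the shared core carrying different groups.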